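A Branched Aromatic Amide Replaces the Hydroxyhexyl Chain

The source may hold more compounds than are shown below. What is called first, only, known or untested is meant among the compounds shown, and "the series" means these compounds.

Compound 2 `CCCCCCCCCCCC(=O)OC[C@H](CSC[C@@H](N)C(=O)NCCCCCCO)OC(=O)CCCCCCCCCCC` gives 33 nM in an assay on HEK293 cells for agonist activity at Toll-like receptor 2 (Homo sapiens) (on this read-out lower numbers stand for an effect already at smaller amounts and higher numbers for an effect only at larger amounts of compound), the lowest of the three measured numbers; compound 3 `CCCCCCCCCCCC(=O)OC[C@H](CSC[C@@H](N)C(=O)NCCOCCOS(=O)(=O)O)OC(=O)CCCCCCCCCCC` gives 61 nM, and the two lie within the scatter of each other, while compound 1 `CCCCCCCCCCCC(=O)OC[C@H](CSC[C@@H](N)C(=O)NC(C)(C)CO)OC(=O)CCCCCCCCCCC` gives 15500 nM. Compound 4 `CCCCCCCCCCCC(=O)OC[C@H](CSC[C@@H](N)C(=O)NC(C)c1ccccc1)OC(=O)CCCCCCCCCCC` carries 1-phenylethyl in place of 6-hydroxyhexyl on an amide-type nitrogen. The relevant comparisons are a 470-fold lower number from compound 1 to compound 2 (2.67 log units; beyond the scatter) and a 250-fold lower number from compound 1 to compound 3 (2.41 log units; beyond the scatter): the branched 1-(hydroxymethyl)-1-methylethyl group of compound 1 goes with a far higher number than either straight hydroxyl-bearing chain. The 1-phenylethyl group is also branched and has no hydroxyl, so a large rise is expected, a 45-fold higher number from compound 2 to compound 4 (1.66 log units; beyond the scatter). Compound 4 is therefore estimated at 1500 nM in this assay, most likely between 200 nM and 12000 nM.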

Compound 4, half-maximal effective concentration: 9900 nM
Compound 4: the middle estimate sits 6.6-fold (0.82 log units) below what was measured, and the stated range covers the measured number.
By their numbers in this assay, from the lowest: compounds 2 and 3 (each within the scatter of the next); then compounds 4 and 1 (each within the scatter of the next).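

In this assay, replacing either straight chain with 1-phenylethyl gives a large rise (a 300-fold higher number from compound 2 to compound 4 (2.48 log units; beyond the scatter); a 160-fold higher number from compound 3 to compound 4 (2.21 log units; beyond the scatter)), yet compound 4 stays within the scatter of compound 1 (a 1.6-fold lower number from compound 1 to compound 4 (0.19 log units; within the scatter)). Two branched groups, one with a hydroxyl and one with an aromatic ring and no hydroxyl, thus end up level on the amide-type nitrogen, and all four compounds fit the split between branched and straight groups. No measurement here explains this split.

As far as these compounds go, whether branching, lost chain length or something else drives the rise remains open. A plain hexyl chain or an unbranched benzyl group would help separate these.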